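The source may hold more compounds than are shown below. What is called first, only, known or untested is meant among the compounds shown, and "the series" means these compounds.

Compound 1 `CCn1nc(Cc2ccc(SC)cc2)c2ccccc2c1=O` carries a methylsulfanyl group on its outer aromatic ring and an ethyl group on the aromatic nitrogen of the shared core. In a functional assay on aorta with Alpha-1D adrenergic receptor (Rattus norvegicus) as the target (a higher number here means that more compound is needed for the effect, a lower number that less compound is needed), compound 1 gives only > 100000 nM, which is a limit of the assay rather than a number. Compound 2 `CCn1nc(Cc2ccc(Cl)cc2)c2ccccc2c1=O` differs from compound 1 by chloro in place of methylsulfanyl on an aromatic carbon, and in this assay compound 2 gives 1300 nM. That step, an at least 76-fold lower number from compound 1 to compound 2 (1.88 log units; beyond the scatter), rests at one end on (the limit of > 100000 nM in this assay, at which 1 of the 2 values shown sits), so only its lower bound is known. Compound 3 `CSc1ccc(Cc2nn(-c3ccc(Br)cc3)c(=O)c3ccccc23)cc1` differs from compound 1 in another place: 4-bromophenyl in place of ethyl on an aromatic nitrogen. Going by the values given here, no measured step touches the aromatic nitrogen, so the step from compound 1 to compound 2 gives no direct guide to this change, and the starting point itself is known only as a limit. The expectation for compound 3 is therefore broad: an estimated value of 60000 nM, expected to lie between 10000 nM and 300000 nM. The expected step for compound 3 is then an at least 1.6-fold lower number from compound 1 to compound 3 (0.22 log units; that floor lies within the scatter).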

Compound 3, half-maximal effective concentration: > 100000 nM
Compound 3 gave a limit, no number; the forecaster's own chance of this, stated with the estimate: 55%; at least 1.6-fold (0.22 log units) between middle value and limit.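

In this assay compound 3 gives > 100000 nM, which is a limit of the assay and not a number. Compound 1 also sits at a limit, so no step can be read between compound 1 and compound 3: the limit of > 100000 nM in this assay, at which 2 of the 3 values shown sit.

The compounds shown leave open whether 4-bromophenyl in place of ethyl on an aromatic nitrogen changes the number at all.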